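The compounds below may be only part of what the source reports. "The series", "measured", "known", "first", "only" and "open" are said of these compounds alone.

Working notes on the series. Compound 1 `CCCc1csc(CN[C@@H]2C[C@H]3C[C@@H]([C@H]2C)C3(C)C)c1`, compound 2 `C[C@H]1[C@H](NCc2ccsc2)C[C@H]2C[C@@H]1C2(C)C` and compound 3 `C[C@H]1[C@H](NCc2cccs2)C[C@H]2C[C@@H]1C2(C)C` share one core and differ only at the aromatic ring on the amine side. In an ADME assay on MDCK cells (Canis lupus familiaris) for cytotoxicity, read by microscopy, with a stated time of 48 h (on this read-out higher numbers stand for lower toxicity in this test and lower numbers for higher toxicity in this test), compound 1 gives 12500 nM, compound 2 gives 50000 nM and compound 3 gives 25000 nM. Compound 3 thus stands second highest of the three numbers, but both gaps are within the scatter: a 2.0-fold higher number from compound 1 to compound 3 (0.30 log units; within the scatter), and a 2.0-fold lower number from compound 2 to compound 3 (0.30 log units; within the scatter). Compound 4 `CCCCc1ccsc1CN[C@@H]1C[C@H]2C[C@@H]([C@H]1C)C2(C)C` differs from compound 3 by butyl in place of hydrogen on an aromatic carbon. Going by the values given here, the only step that bears on an alkyl group on the ring is a 2.0-fold higher number from compound 1 to compound 3 (0.30 log units; within the scatter), run in the opposite sense and within the scatter, so no move beyond the scatter is expected here either. Compound 4 is expected to give about 10000 nM, between 4000 nM and 30000 nM. The expected step is a 2.5-fold lower number from compound 3 to compound 4 (0.40 log units; beyond the scatter).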

Compound 4, minimum cytotoxic concentration: 25000 nM
For compound 4 the middle estimate is 2.5-fold (0.40 log units) below the measured one; low and high end bracket the measured number.
By their numbers in this assay, from the lowest: compounds 1, 3, 4 and 2 (each within the scatter of the next, the first and the last beyond it).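

In this assay butyl in place of hydrogen on the aromatic carbon two ring bonds from the ring sulfur gives no change at the digits printed from compound 3 to compound 4 (within the scatter) and so leaves the read-out where it stood. Going by these compounds alone, the earlier compounds carried no alkyl group at this position, so this is the first sign that butyl can sit here without a move beyond the scatter. No measurement in hand offers a reason for this result. From the compounds shown here alone, whether a longer chain, an amine or a carboxylic acid at this position would move the number beyond the scatter stays open.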